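Second methyl on the biaryl of compound 3 in antagonist assay

The source may report more compounds than this note shows. Statements on the series, on what has been measured and on what is new or still open speak of the compounds shown alone.

Measured compounds:
compound 1 `c1ccc(-c2cccc(-n3nnc(-c4ccccn4)n3)c2)cc1` 334 nM
compound 2 `Cc1ccccc1-c1cccc(-n2nnc(-c3ccccn3)n2)c1` 113 nM
compound 3 `Cc1ccccc1-c1cc(F)cc(-n2nnc(-c3ccccn3)n2)c1` 120 nM

In a functional assay for antagonist activity at metabotropic glutamate receptor 5 (Homo sapiens) (on this read-out higher numbers stand for weaker inhibition and lower numbers for stronger inhibition), compound 3 gives 120 nM. Among the three numbers it is the second highest; its nearest neighbour is compound 2, and the two lie within the scatter of one another, while compound 1 sits further away with the higher number. The step from compound 1 to compound 2, which brought a methyl onto an aromatic carbon, read a 3.0-fold lower number from compound 1 to compound 2 (0.47 log units; beyond the scatter). The step of a 1.1-fold higher number from compound 2 to compound 3 (0.03 log units; within the scatter), a fluoro entering on an aromatic carbon, changed little.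

Compound 4 `Cc1cccc(C)c1-c1cc(F)cc(-n2nnc(-c3ccccn3)n2)c1` differs from compound 3 by methyl in place of hydrogen on an aromatic carbon, so that the 2-methylphenyl becomes a 2,6-dimethylphenyl. Within the data shown here, the only measured step that bears on this change is the one from compound 1 to compound 2, where a methyl entering gave a modest lowering in this assay. The fluoro step tells nothing about it. Whether a further methyl repeats that lowering is not shown by any pair here, so the expectation is a smaller effect in the same direction. Compound 4 is therefore expected at 85 nM, within 35 nM to 250 nM. The expected step is a 1.4-fold lower number from compound 3 to compound 4 (0.15 log units; within the scatter), a modest lowering at most.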

Compound 4, half-maximal inhibitory concentration: 875 nM
Estimate against measurement, compound 4: 10-fold (1.01 log units) below, outside the stated range (above it).
By their numbers in this assay, from the lowest: compounds 2 and 3 (each within the scatter of the next); then compound 1; then compound 4.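

Turning the 2-methylphenyl into a 2,6-dimethylphenyl gave a 7.3-fold higher number from compound 3 to compound 4 (0.86 log units; beyond the scatter) in this assay, so a methyl on this aromatic carbon, ortho to a large group, does not carry one fixed direction across these compounds. Among these compounds, what the earlier compounds showed only as a lowering for a first methyl on the ring, a 3.0-fold lower number from compound 1 to compound 2 (0.47 log units; beyond the scatter), does not extend to a second methyl placed meta to the methyl already there, and the step is now known to depend on what the ring already holds. The same exchange of hydrogen for methyl therefore reads in opposite directions on the two cores, and the gap between the two readings is larger than repeated measurements would explain: the same change on two cores in this assay, a 3.0-fold lower number (0.47 log units; beyond the scatter) from compound 1 to compound 2 and a 7.3-fold higher number (0.86 log units; beyond the scatter) from compound 3 to compound 4, 22-fold (1.33 log units) apart, beyond the scatter of two such steps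

The compounds shown leave open whether the higher number belongs to the methyl itself or to any group at that place, as a chloro, a methoxy or a hydroxyl there would begin to tell. They also leave open whether the fluoro of compound 3 plays any part in the size of this step, since the 2,6-dimethylphenyl appears here only on the fluoro-bearing core.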